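Bromo in Place of Fluoro: Will the Swap Matter?

The source may report more compounds than this note shows. Statements on the series, on what has been measured and on what is new or still open speak of the compounds shown alone.

compound 1 `CN(C)C(=S)N/N=C/c1ccc2ccccc2n1` — 20 nM
compound 2 `Fc1ccccc1NC(=S)N/N=C/c1ccc2ccccc2n1` — > 100000 nM
compound 3 `NC(=S)N/N=C/c1ccc2cccnc2n1` — 12800 nM

In a functional assay on HT-29 cells (Homo sapiens) for antiproliferative activity, read by sulforhodamine B assay, with a stated time of 72 h (on this read-out lower numbers stand for stronger inhibition and higher numbers for weaker inhibition), compound 1 gives 20 nM and compound 3 gives 12800 nM. For compound 2 the assay reports no number, only a limit, > 100000 nM. Compound 2 therefore sits at the limit of > 100000 nM in this assay, at which 1 of the 3 values shown sits, with no measured point of its own among the values shown.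

Compound 4 `S=C(N/N=C/c1ccc2ccccc2n1)Nc1ccccc1Br` differs from compound 2 in a single place: bromo in place of fluoro on an aromatic carbon. For the measured compounds named here, no pair of measured compounds shows the size of such a swap, so nothing here sizes it directly. Compound 4 is expected to remain weak, with an at least 2.0-fold lower number from compound 2 to compound 4 (0.30 log units; that floor lies within the scatter) amounting to a modest gain at best. The estimate for compound 4 is 50000 nM, ranging from 5000 nM to 200000 nM.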

Compound 4, half-maximal inhibitory concentration: > 100000 nM
Compound 4: a limit, no number; the forecaster's own chance of this, stated with the estimate: 50%; middle value at least 2.0-fold (0.30 log units) away from the limit.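

Compound 2 and compound 4 each give only a limit, not a number, so the step between them cannot be read: the limit of > 100000 nM in this assay, at which 2 of the 4 values shown sit.

The compounds shown leave open how much, if at all, bromo in place of fluoro changes activity.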